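The compounds below may be only part of what the source reports. "The series", "measured", "known", "first", "only" and "open" are said of these compounds alone.

Compound 3 `COCCOC(=O)N1CCC(Oc2ncnc3c2CCN3c2ccc(S(C)(=O)=O)cc2F)CC1` gives in a functional assay on CHO-K1 cells with Glucose-dependent insulinotropic receptor (Homo sapiens) as the target, read by a luciferase reporter, with a stated time of 5 h (on this read-out lower numbers stand for smaller maximal responses and higher numbers for larger maximal responses), a maximal response of 86%. Among the three measured compounds it stands second highest: compound 2 `CC(C)(C)COC(=O)N1CCC(Oc2ncnc3c2CCN3c2ccc(S(C)(=O)=O)cc2F)CC1` gives 80%, and the step of a number 6 percentage points higher from compound 2 to compound 3 (within the scatter) lies within the scatter, whereas compound 1 `CCOC(=O)N1CCC(Oc2ncnc3c2CCN3c2ccc(S(C)(=O)=O)cc2F)CC1` gives 135%, so that the step of a number 49 percentage points lower from compound 1 to compound 3 (beyond the scatter) is large. The remaining measured step, a number 55 percentage points lower from compound 1 to compound 2 (beyond the scatter), is of similar size. All three measured compounds differ only in the chain bound to the oxygen of the same carbonyl group on the ring nitrogen.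

Compound 4 `CS(=O)(=O)c1ccc(N2CCc3c(OC4CCN(C5=NCCCN5)CC4)ncnc32)c(F)c1` changes a different part of the molecule: a group of 6 heavy atoms (4 carbon, 2 nitrogen; one six-membered non-aromatic ring with 2 hetero atoms) in place of a group of 7 heavy atoms (4 carbon, 3 oxygen; no ring), on an amine nitrogen in a ring. Among the compounds with values here, none of the measured steps touches this part; they show only that altering the chain bound to the oxygen can shift the response markedly, and that compounds 2 and 3 lie close together. The group that enters brings a hydrogen-bond donor and a ring where there was none, and the carbonyl is gone. Within the data shown here, with no comparable step to draw on, the expectation for compound 4 is uncertain, but a step of a number 16 percentage points lower from compound 3 to compound 4 (beyond the scatter) is expected. The maximal response of compound 4 is therefore estimated at 70%, within a range from 20% to 125%.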

Compound 4, largest response reached (reported as percent of maximum), in percent of the reference or control that the assay uses: 66%
Compound 4: the middle estimate sits 4 percentage points above what was measured; the measured number falls inside the stated range.
By their numbers in this assay, from the lowest: compound 4; then compounds 2 and 3 (each within the scatter of the next); then compound 1.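

In this assay, within the data shown here, compound 4 shows that a carbonyl on the amine nitrogen in a ring is not required for a response, since its six-membered non-aromatic ring with 2 hetero atoms carries a response of 66% without one, whereas the earlier compounds varied only the chain beyond a retained carbonyl. The replacement gives a number 20 percentage points lower from compound 3 to compound 4 (beyond the scatter) and a number 14 percentage points lower from compound 2 to compound 4 (beyond the scatter), both modest, together with a number 69 percentage points lower from compound 1 to compound 4 (beyond the scatter), which is large, so that compound 4 stands lowest of the four and the change from the (2-methoxyethoxy)carbonyl group costs less than the gap separating compound 1 from compound 3. No measurement at hand accounts for these differences.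

The step exchanges the carbonyl, the open chain and the hydrogen-bond donor count all at once, so the share of each in the lower response stays unresolved. On these data alone, a urea carrying an ethyl chain or a plain ethyl group on the same nitrogen could help separate these contributions, and whether the high response of compound 1 can be reached without a carbonyl remains open.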